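Two Amino Groups in Place of Iodine on the Sulfonyl Arene

The source may hold more compounds than are shown below. What is called first, only, known or untested is meant among the compounds shown, and "the series" means these compounds.

Compound 1 `COc1cc2nc(N3CCN(S(=O)(=O)c4ccc(Cl)cc4)CC3)nc(N)c2cc1OC` gives 23000 nM in a functional assay on PC-3 cells (Homo sapiens) for inhibition; on this read-out lower numbers stand for stronger inhibition and higher numbers for weaker inhibition.
Compound 2 `COc1cc2nc(N3CCN(S(=O)(=O)c4ccc(I)cc4)CC3)nc(N)c2cc1OC` gives 15000 nM in this assay.

Both numbers sit in the weak range, and compound 2 stands next to compound 1 rather than apart from it: a 1.5-fold lower number from compound 1 to compound 2 (0.19 log units; within the scatter). That single step is the whole of what has been measured, and it concerns only the exchange of one halogen for another on the same arene.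

Compound 3 `COc1cc2nc(N3CCN(S(=O)(=O)c4ccc(N)cc4N)CC3)nc(N)c2cc1OC` has not yet been measured. It differs from compound 2 in one place: 2,4-diaminophenyl in place of 4-iodophenyl on a sulfonyl sulfur. Among the compounds with values here, no measured step bears on this kind of exchange; the halogen swap between compound 1 and compound 2 stayed inside the scatter and says nothing about what two amino groups would do. With nothing pointing in either direction, no movement beyond the scatter is expected in this assay. The estimate for compound 3 is 20000 nM, with a range from 5000 nM to 80000 nM. This estimate means an expected step of a 1.3-fold higher number from compound 2 to compound 3 (0.12 log units; within the scatter).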

Compound 3, half-maximal inhibitory concentration: 67000 nM
Compound 3: middle estimate off by 3.4-fold (0.53 log units), on the low side; measured number inside the range.
By their numbers in this assay, from the lowest: compounds 2 and 1 (each within the scatter of the next); then compound 3.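

The sulfonyl sulfur's aryl group is not indifferent in this assay: although the halogen exchange stayed within the scatter, placing 2,4-diaminophenyl there in place of 4-iodophenyl gives a 4.5-fold higher number from compound 2 to compound 3 (0.65 log units; beyond the scatter), and placing it there in place of 4-chlorophenyl gives a 2.9-fold higher number from compound 1 to compound 3 (0.46 log units; beyond the scatter). Both steps are modest and run towards weaker inhibition, so changing this aryl group can move the number beyond the scatter while the shared core stays the same. The entering group carries hydrogen-bond donors and acceptors where 4-iodophenyl has none, but no measurement here connects that difference with the result.

Since the two amino groups enter together, the compounds shown leave open whether a single amino group would give a comparable step, and whether either amino group contributes more than the other. They also leave open how the number would respond to a carboxylic acid, a methoxy group or an acetamide on the same arene, and so whether other replacements for the halogen would also weaken inhibition.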